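The compounds below may be only part of what the source reports. "The series", "measured", "known", "first", "only" and "open" are said of these compounds alone.

Measured compounds:
- compound 1, `O=C1N=C(C2C(=O)c3ccccc3C2=O)CC(c2cccc([N+](=O)[O-])c2)N1`: 12%
- compound 2, `O=C1N=C(C2C(=O)c3ccccc3C2=O)CC(c2ccc([N+](=O)[O-])cc2)N1`: 18%
- compound 3, `O=C1N=C(C2C(=O)c3ccccc3C2=O)CC(/C=C/c2ccccc2)N1`: 16%

All three were tested in a functional assay on the whole organism for inhibition, with Rattus norvegicus as the target, read by paw edema, with stated times of 30 min and 4 h, at a dose of 10 mg/kg by the oral route; on this read-out higher numbers stand for more inhibition at the one dose given (going by the name of the read-out) and lower numbers for less inhibition. Compound 1 gives 12% in this assay, and on the numbers shown it sits at the bottom of the three. The gaps are small, however: a number 6 percentage points higher from compound 1 to compound 2 (within the scatter) and a number 4 percentage points higher from compound 1 to compound 3 (within the scatter) both lie within the usual scatter, so the three compounds cannot be told apart on this read-out.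

The new compound 4, `O=C1N=C(C2C(=O)c3ccccc3C2=O)CC(c2ccccc2O)N1`, differs from compound 1 at the same place where compound 2 and compound 3 differ from it: 2-hydroxyphenyl in place of 3-nitrophenyl on a saturated ring carbon. Within the data shown here, the steps that bear on this change are a number 6 percentage points higher from compound 1 to compound 2 (within the scatter) and a number 4 percentage points higher from compound 1 to compound 3 (within the scatter), both within the scatter. Swapping the group on that saturated ring carbon has so far produced no step beyond the scatter in this assay, and nothing in the data points to the 2-hydroxyphenyl behaving differently.

Compound 4 is therefore expected to give about 15%, in a range from 5% to 28%. The step this estimate means, a number 3 percentage points higher from compound 1 to compound 4 (within the scatter), is expected to stay within the scatter.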

Compound 4, a percentage reported as inhibition, in the whole organism at one dose (the size of the read-out at that dose, not a potency): 16%
Beside the measured number, compound 4's estimate is 1 percentage points below it; the measured number falls inside the stated range.
By their numbers in this assay, from the lowest: compounds 1, 3, 4 and 2 (each within the scatter of the next).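

In this assay, 2-hydroxyphenyl on the saturated ring carbon gives a number 4 percentage points higher from compound 1 to compound 4 (within the scatter), no change at the digits printed from compound 3 to compound 4 (within the scatter) and a number 2 percentage points lower from compound 2 to compound 4 (within the scatter). Unlike 3-nitrophenyl, this group carries a hydrogen-bond donor, yet that exchange gives no step beyond the scatter, so the position has now taken one more kind of group and the four compounds still cannot be told apart on this read-out. No measurement at hand explains these numbers.

Every group shown at this position contains a phenyl ring, so it remains open what a plain butyl chain, or a phenyl ring bearing an amine or a carboxylic acid, would give there. The compounds also leave open whether a change elsewhere on the shared core would move the number beyond the scatter.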